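The source may report more compounds than this note shows. Statements on the series, on what has been measured and on what is new or still open speak of the compounds shown alone.

Measured so far in a functional assay on the whole organism (strain Wistar) for inhibition, with Rattus norvegicus as the target, read by paw edema, with stated times of 60 min and 2 h, at a dose of 100 mg/kg by the oral route; a lower number here means less inhibition, a higher number more inhibition at the dose given (going by the name of the read-out):
compound 1, `COc1cc2c(cc1OC)C(CC(N)=O)CC2`: 31%
compound 2, `COc1cc2c(cc1OC)C(CC(=O)N(C)C)CC2`: 36%
compound 3, `CCCCNC(=O)CC1CCc2cc(OC)c(OC)cc21`: 24%

Compound 3 stands at the lowest of the three numbers. The nearest number is that of compound 1: a number 7 percentage points lower from compound 1 to compound 3 (within the scatter), a gap within the scatter. The furthest is that of compound 2: a number 12 percentage points lower from compound 2 to compound 3 (beyond the scatter), the only gap in the set that lies beyond the scatter.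

Next to be measured is compound 4, `COc1cc2c(cc1OC)C(CC(=O)N1CCCC1)CC2`. The change from compound 3 is pyrrolidin-1-yl in place of butylamino on a carbonyl carbon. Among the compounds with values here, two measured steps bear on it. The first, a number 5 percentage points higher from compound 1 to compound 2 (within the scatter), shows that amino and dimethylamino on the carbonyl carbon give numbers indistinguishable within the scatter. The second, a number 12 percentage points lower from compound 2 to compound 3 (beyond the scatter), is the modest drop from dimethylamino to butylamino. Pyrrolidin-1-yl, like dimethylamino, carries no hydrogen-bond donor, whereas butylamino carries one; on the evidence of the step from compound 2 to compound 3, the change is expected to recover roughly that amount, although with only three numbers the expectation is loose.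

Compound 4 is therefore expected to give 33% in this assay, within 22% to 44%. The expected step is a number 9 percentage points higher from compound 3 to compound 4 (within the scatter), at the edge of the scatter.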

Compound 4, a percentage reported as inhibition, in the whole organism at one dose (the size of the read-out at that dose, not a potency): 20%
Compound 4: middle estimate off by 13 percentage points, on the high side, outside the stated range (below it).
By their numbers in this assay, from the lowest: compounds 4, 3, 1 and 2 (each within the scatter of the next, the first and the last beyond it).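

In this assay, the exchange of butylamino for pyrrolidin-1-yl gives a number 4 percentage points lower from compound 3 to compound 4 (within the scatter), so these two groups of equal heavy-atom count, one with a hydrogen-bond donor and one without, are not told apart at this carbonyl carbon. Pyrrolidin-1-yl also does not read like dimethylamino, with a number 16 percentage points lower from compound 2 to compound 4 (beyond the scatter), so the absence of a hydrogen-bond donor does not by itself sort compound 2 and compound 4 together. Within the data shown here, with a number 11 percentage points lower from compound 1 to compound 4 (beyond the scatter), pyrrolidin-1-yl is the first group set apart from both amino and dimethylamino, whereas butylamino stood apart from dimethylamino only.

No available measurement accounts for these differences.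

Open, as far as these compounds go, is how piperidin-1-yl, morpholin-4-yl or diethylamino on the same carbonyl carbon would read, and so whether the separation of compound 4 from compound 2 belongs to the pyrrolidine ring or to something narrower. Also open, from the compounds shown here alone, is whether a carboxylic acid in place of the amide, or a longer chain between the carbonyl and the shared core, would move the number beyond the scatter of these four compounds.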